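This account rests on a few compounds, and the source may have more. Where it says the series, first, only, none or still open, it means among the compounds named here.

Working notes on the series. Three compounds share one core and differ in the amine on the pyrazole and in the group on its other side. Compound 1 `CC(C)NCc1cn(CC(=O)Nc2sc3c(c2C(N)=O)CCCC3)nc1C(C)(C)C` gives 1580 nM in an assay on isolated protein with metabotropic glutamate receptor 1 (Homo sapiens) as the target; on this read-out higher numbers stand for an effect only at larger amounts of compound and lower numbers for an effect already at smaller amounts. Compound 2 `CN(C)Cc1cn(CC(=O)Nc2sc3c(c2C(N)=O)CCCC3)nc1C(F)(F)F` gives 501 nM in this assay. Compound 3 `CCN(CC)Cc1cn(CCC(=O)Nc2sc3c(c2C(N)=O)CCCC3)nc1C(F)(F)F` gives 2000 nM in this assay, the highest of the three numbers; its value and that of compound 1 lie within the scatter of each other, while compound 2 gives a number beyond the scatter below that of compound 3. Among the compounds with values here, no single-point step between the measured compounds is available, so these are only pairwise readings.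

Compound 4 `CCNCc1cn(CCC(=O)Nc2sc3c(c2C(N)=O)CCCC3)nc1C(F)(F)F` is not yet measured. Its difference from compound 3 is hydrogen in place of ethyl on an amine nitrogen. Within the data shown here, the measured compounds contain no matched pair that isolates this change, so no direction is supported by data. The step from compound 3 to compound 4 in this assay is expected to be no change at the digits printed from compound 3 to compound 4 (within the scatter), which is no step beyond the scatter. Compound 4 is therefore estimated at 2000 nM, with a range from 800 nM to 5000 nM.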

Compound 4, half-maximal effective concentration: 2510 nM
Estimate against measurement, compound 4: 1.3-fold (0.10 log units) below; the range from low to high includes it.
By their numbers in this assay, from the lowest: compound 2; then compounds 1, 3 and 4 (each within the scatter of the next).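

Within the data shown here, this is the first single-place step: in this assay, hydrogen in place of ethyl on the amine nitrogen gives a 1.3-fold higher number from compound 3 to compound 4 (0.10 log units; within the scatter). On this pair, diethylamino and ethylamino therefore cannot be told apart, so the second ethyl on the nitrogen is not needed to keep the reading of compound 3 in this assay. Nothing on hand offers an explanation for this reading.

The compounds shown leave open how an unsubstituted amino group or a piperidine would read in place of these amines. They also leave open whether hydrogen in place of ethyl on this nitrogen would read the same way on a compound with the shorter chain of compound 2, or with the tert-butyl group of compound 1.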